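A Group Swap in a Weakly Active Series

A few compounds are considered here, and "the series" means these few. Any claim that something is new, unique, unknown or untested is made for them only; others in the source may bear on it.

Measured in a functional assay on HepG2 cells (Homo sapiens) for antiproliferative activity, read by MTT assay (a higher number here means a weaker inhibitor, a lower number a stronger inhibitor), so far:
- compound 1 `CC1(C)CCc2cc(C(=O)/C=C/c3ccc(OCc4cn(-c5ccc(Br)cc5)nn4)cc3)c(O)cc2O1` gives "not active" (no number reported)
- compound 2 `CCc1ccccc1-n1cc(COc2ccc(/C=C/C(=O)c3cc4c(cc3O)OC(C)(C)CC4)cc2)nn1` gives 115000 nM
- compound 3 `CC1(C)CCc2c(ccc(C(=O)/C=C/c3ccc(OCc4cn(-c5ccc(Cl)cc5)nn4)cc3)c2O)O1` gives 102000 nM

Only two of these compounds have a number. Compound 3 at 102000 nM lies within the usual scatter of compound 2 at 115000 nM and the two cannot be told apart.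

The next compound, compound 4 `COc1ccc(-n2cc(COc3ccc(/C=C/C(=O)c4ccc5c(c4O)CCC(C)(C)O5)cc3)nn2)c([N+](=O)[O-])c1`, keeps the core of compound 3 and changes one group. The change is 4-methoxy-2-nitrophenyl in place of 4-chlorophenyl on an aromatic nitrogen and in short it puts 4-methoxy-2-nitrophenyl in place of 4-chlorophenyl on an aromatic nitrogen.

Going by the values given here, no measured pair here differs in only one place, so the data do not show directly how far such a swap moves the number in this assay or in which direction. The two available numbers are close together, which leads to an expectation of no step beyond the scatter. Compound 1 with its result of "not active" (no number reported) is a caution that a compound in this set may yield no number at all.

The estimated step is a 1.0-fold lower number from compound 3 to compound 4 (0.01 log units; within the scatter) and it is expected to stay within the scatter. For compound 4 the expected value is 100000 nM with an estimated range from 40000 nM to 250000 nM for this measurement.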

Compound 4, half-maximal inhibitory concentration: 120000 nM
Estimate against measurement, compound 4: 1.2-fold (0.08 log units) below, and the stated range covers the measured number.
By their numbers in this assay, from the lowest: compounds 3, 2 and 4 (each within the scatter of the next).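

In this assay, going by these compounds alone, putting 4-methoxy-2-nitrophenyl in place of 4-chlorophenyl on an aromatic nitrogen of the five-membered ring gives a 1.2-fold higher number from compound 3 to compound 4 (0.07 log units; within the scatter), the first direct reading of a group swap at this position. Within the data shown here, the entering group is larger than the one that leaves and carries hydrogen-bond acceptors that 4-chlorophenyl lacks, yet this exchange leaves the two compounds indistinguishable in this measurement, so these added atoms and the new substitution two ring bonds from the ring nitrogen produce no step that can be told from ordinary assay variation. The data offer no measured explanation for this outcome, so it stands only as an observation about this one pair.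

A single swap cannot show whether the methoxy and nitro groups each have no effect or whether separate effects happen to cancel, and a phenyl ring carrying only one of them would be needed to tell these cases apart. As far as these compounds go, it also remains open whether a group of a different kind at this position, such as an amine, a carboxylic acid or a longer alkyl chain, would move the number beyond the scatter.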